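Cytotoxicity notes: from compound 2 to compound 3

The source may hold more compounds than are shown below. What is called first, only, known or untested is meant among the compounds shown, and "the series" means these compounds.

Within the data shown here, in an ADME assay on HEK-293T cells (Homo sapiens) for cytotoxicity, read by luminescence, with a stated time of 24 h (a lower number here means that less compound is tolerated, a higher number that more compound is tolerated), compound 2 (`CCCNC(=O)C1CCN(C(=O)c2cc3sc(CNC(C)c4ccccc4)cc3n2Cc2ccc(OC)cc2)CC1`) gives 33900 nM, the only actual number so far. Compound 1 (`CCOC(=O)c1cc2sccc2n1Cc1ccc(OC)cc1`) reads > 100000 nM, which is a limit of the assay and not a number.

Compound 3 (`CCCNC(=O)C1CCN(C(=O)c2cc3sc(C#N)cc3n2Cc2ccc(OC)cc2)CC1`) has not yet been measured in this assay. It differs from compound 2 by cyano in place of ((1-phenylethyl)amino)methyl on an aromatic carbon, next to the ring sulfur. Among the measured compounds shown here, no step between measured compounds is available to size this change, so the expectation is a judgement resting on two readings. For the measured compounds named here, the direction expected is towards more compound tolerated, since compound 2 at 33900 nM sits on the less tolerated side of the only other reading. The expected change, a 2.2-fold higher number from compound 2 to compound 3 (0.34 log units; beyond the scatter), is modest and may not clear the usual scatter by much, and a reading that returns only a limit is a real possibility. Compound 3 is estimated at 75000 nM, with an expected range of 35000 nM to 150000 nM.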

Compound 3, half-maximal cytotoxic concentration: > 100000 nM
Compound 3: a limit, no number (the forecaster's own chance of this, stated with the estimate: 45%); middle value at least 1.3-fold (0.12 log units) away from the limit.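

Compound 3 reads > 100000 nM in this assay, which is a limit of the assay and not a number. Among these compounds, exchanging ((1-phenylethyl)amino)methyl for cyano on this aromatic carbon, next to the ring sulfur, gives an at least 2.9-fold higher number from compound 2 to compound 3 (0.46 log units; beyond the scatter), the first single-place step, and it shows that the measurable reading of compound 2 does not persist once that group leaves, although the rest of the structure stays the same. The step can be sized only from one side, and the series now offers little room to read further gains: the limit of > 100000 nM in this assay, at which 2 of the 3 values shown sit.

The compounds shown leave open which part of the departing group goes with the lower number of compound 2, the amine or the six-membered aromatic ring, a question that a plain aminomethyl group or a benzyl group at this carbon would help to separate. From the compounds shown here alone, it also remains open whether a carboxylic acid or a longer alkyl chain at this carbon would give a reading with an actual number in this assay.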